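The source may hold more compounds than are shown below. What is called first, only, known or untested is meant among the compounds shown, and "the series" means these compounds.

In a functional assay on SH-SY5Y cells (Homo sapiens) for cytotoxicity, read by MTT assay, with stated times of 24 h and 4 h (a lower number here means that less compound is needed, a higher number that more compound is needed for the effect), three compounds have been measured so far:

Compound 1 `COc1cc(CNC(=O)/C=C/c2cccc(OCc3nc(C)c(C)nc3C)c2)ccc1OCc1nc(C)c(C)nc1C` gives 8700 nM.
Compound 2 `COc1cc(CNC(=O)/C=C/c2ccc(OC)c(OCc3nc(C)c(C)nc3C)c2)ccc1OCc1nc(C)c(C)nc1C` gives 11600 nM.
Compound 3 `COc1ccc(OC)c(/C=C/C(=O)NCc2ccc(O)c(OC)c2)c1` gives 9500 nM.

Compound 2 carries one change relative to compound 1: methoxy in place of hydrogen on an aromatic carbon. In this assay this gave a 1.3-fold higher number from compound 1 to compound 2 (0.12 log units; within the scatter). Compound 4 `COc1cc(CNC(=O)/C=C/c2cc(OC)c(OC)cc2OC)ccc1O` has not been measured; it differs from compound 3 by the same kind of change, (methoxy in place of hydrogen on an aromatic carbon). The surroundings are not identical: in compound 2 the new group is ortho to a (3,5,6-trimethylpyrazin-2-yl)methoxy group, in compound 4 it is ortho to a methoxy group and meta to a methoxy group, and in both it is para to a large group. The difference between the core of compound 1 and the core of compound 3 is not broken down here. Because the earlier step of a 1.3-fold higher number from compound 1 to compound 2 (0.12 log units; within the scatter) stayed within the scatter, a similarly small step is expected here: a 1.2-fold higher number from compound 3 to compound 4 (0.06 log units; within the scatter). Compound 4 is therefore estimated at 11000 nM in this assay.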

Compound 4, half-maximal effective concentration: 2410 nM
For compound 4 the middle estimate is 4.6-fold (0.66 log units) above the measured one, outside the stated range (below it).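

In this assay, methoxy in place of hydrogen on an aromatic carbon gave a 3.9-fold lower number from compound 3 to compound 4 (0.60 log units; beyond the scatter). The same change stayed within the scatter on the core of compound 1, so its result on one core did not carry over to the other: the same change on two cores in this assay, a 1.3-fold higher number (0.12 log units; within the scatter) from compound 1 to compound 2 and a 3.9-fold lower number (0.60 log units; beyond the scatter) from compound 3 to compound 4, 5.3-fold (0.72 log units) apart, beyond the scatter of two such steps This does not show which difference between the two cores, or in the surroundings of the new group, is responsible, and each step rests on a single pair of compounds. The compounds shown leave open whether an ethoxy group, a fluorine or an amine in the same place on the core of compound 3 would lower the number as methoxy does.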